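Swapping phenyl for anilino on a carbonyl carbon

This account rests on a few compounds, and the source may have more. Where it says the series, first, only, none or still open, it means among the compounds named here.

compound 1 `Cc1ccc(S(=O)(=O)N[C@@H](CC(=O)NC(C)(C)C)C(=O)NCCNC(=O)c2cc(Cl)ccn2)cc1`: > 11100 nM
compound 2 `Cc1ccc(S(=O)(=O)N[C@@H](CC(=O)NC(C)(C)C)C(=O)NCCNC(=O)c2cccc(O)c2)cc1`: > 11100 nM
compound 3 `Cc1ccc(S(=O)(=O)N[C@@H](CC(=O)NC(C)(C)C)C(=O)NCCNC(=O)c2ccccc2)cc1`: > 11100 nM
compound 4 `Cc1ccc(S(=O)(=O)N[C@@H](CC(=O)NC(C)(C)C)C(=O)NCCNC(=O)Nc2ccccc2)cc1`: not yet measured

In an ADME assay on Karpas-1106P cells (Homo sapiens) for cytotoxicity (on this read-out lower numbers stand for an effect already at smaller amounts and higher numbers for an effect only at larger amounts of compound), compound 3 gives > 11100 nM, which is a limit and not a number. Compound 1 and compound 2 offer no numbers either, and the three share one reading: the limit of > 11100 nM in this assay, at which 3 of the 3 values shown sit.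

Compound 4 keeps the core of compound 3 and changes one group: anilino in place of phenyl on a carbonyl carbon, (anilino in place of phenyl on a carbonyl carbon). Cut one bond further out, this reads benzamido to (phenylcarbamoyl)amino.

The closest measured change is a step that the two limits leave unreadable from compound 1 to compound 3, which has phenyl in place of 4-chloropyridin-2-yl on a carbonyl carbon. Another is a step that the two limits leave unreadable from compound 2 to compound 3, which has hydrogen in place of hydroxy on an aromatic carbon. Neither has a size that can be carried over. Still, none of the three groups tried on that carbonyl carbon brought a number into this assay.

Compound 4 is therefore expected to stay at the limit, with no shift in either direction beyond the scatter. The estimated step is a step that the limit leaves unreadable from compound 3 to compound 4. For compound 4 the estimate is 15000 nM, with an expected range of 6000 nM to 40000 nM.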

Compound 4, half-maximal effective concentration: > 11100 nM
Compound 4 was reported as a limit (the forecaster's own chance of this, stated with the estimate: 85%); the middle value does not contradict the limit.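

In this assay compound 4 gives > 11100 nM, which is a limit and not a number. Among these compounds, no step from compound 1, compound 2 or compound 3 to compound 4 can be read, and all four share one reading: the limit of > 11100 nM in this assay, at which 4 of the 4 values shown sit. The compounds shown leave open at what concentration, if any, each would reach its half-maximal effect on these cells.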